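A few compounds are considered here, and "the series" means these few. Any claim that something is new, unique, unknown or untested is made for them only; others in the source may bear on it.

Four compounds are compared in an assay on cells for inhibition of HSP60/HSP10 (Homo sapiens), with a stated time of 60 min; on this read-out higher numbers stand for weaker inhibition and lower numbers for stronger inhibition. Compound 1 `Cc1ccccc1S(=O)(=O)Nc1ccc2oc(-c3ccccc3)nc2c1` and compound 2 `COc1ccc(Cl)cc1S(=O)(=O)Nc1ccc2oc(-c3ccccc3)nc2c1` share one core, while compound 3 `Cc1ccccc1S(=O)(=O)Nc1ccc(-c2nc3ccccc3o2)cc1` and compound 4 `COc1ccc(Cl)cc1S(=O)(=O)Nc1ccc(-c2nc3ccccc3o2)cc1` share another; the difference between the two cores is not broken down here. In this assay compound 1 gives > 100000 nM, which is a limit of the assay rather than a number. In this assay compound 2 likewise gives > 100000 nM, again a limit. The change between them, (5-chloro-2-methoxyphenyl in place of 2-methylphenyl on a sulfonyl sulfur), gives a step that stays unreadable, a step that the two limits leave unreadable from compound 1 to compound 2, due to the limit of > 100000 nM in this assay, at which 2 of the 3 values shown sit. In this assay, within the data shown here, compound 3 gives 85000 nM, the only number among the three results. The same change, (5-chloro-2-methoxyphenyl in place of 2-methylphenyl on a sulfonyl sulfur), is made from compound 3 to compound 4, so it occurs twice among the four compounds. For compound 4 the estimated step is a 1.4-fold higher number from compound 3 to compound 4 (0.15 log units; within the scatter), resting on compound 3 at 85000 nM and on the unreadable step that the two limits leave unreadable from compound 1 to compound 2. In this assay compound 4 is expected to give roughly 120000 nM, with a range from 40000 nM to 400000 nM, and a limit rather than a number is a real possibility.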

Compound 4, half-maximal inhibitory concentration: > 100000 nM
Compound 4: a limit, no number (the forecaster's own chance of this, stated with the estimate: 55%); the middle value lies beyond the limit too.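

In this assay, putting 5-chloro-2-methoxyphenyl in place of 2-methylphenyl on a sulfonyl sulfur gives an at least 1.1-fold higher number from compound 3 to compound 4 (0.07 log units; that floor lies within the scatter), and this floor does not say how large the real step is. The same change on the core of compound 1 cannot be read, so the two occurrences cannot be set side by side, and the data neither show nor rule out that the change carries from one core to the other. Neither step can be sized because the results pile up at one limit: the limit of > 100000 nM in this assay, at which 3 of the 4 values shown sit.

With only compound 3 giving a number, the compounds shown leave open how the two cores compare once both give readable values, and whether any group on the sulfonyl sulfur brings stronger inhibition. Also open, as far as these compounds go, is what an aryl group carrying an amine or a carboxylic acid would give there in place of 2-methylphenyl, on either core.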